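The source may hold more compounds than are shown below. What is called first, only, known or untested is meant among the compounds shown, and "the series" means these compounds.

- compound 1 `CC(=O)N1CCN(c2ccc(Nc3nccc(-c4c[nH]c5ccccc45)n3)cc2)CC1` gives 33 nM
- compound 2 `CC(=O)N1CCN(c2ccc(Nc3ncc(C#N)c(-c4c[nH]c5ccccc45)n3)cc2)CC1` gives 4 nM

In a functional assay on MV4-11 cells (Homo sapiens) for antiproliferative activity, read by resazurin assay, with a stated time of 72 h (a lower number here means a stronger inhibitor of growth, a higher number a weaker inhibitor of growth), compound 2 has the lower of the two numbers, at 4 nM so far. Compound 3 `CC(=O)N1CCN(c2ccc(Nc3ncc(C#N)c(-c4n[nH]c5ccccc45)n3)cc2)CC1` carries 1H-indazol-3-yl in place of 1H-indol-3-yl on an aromatic carbon and is otherwise unchanged. For the measured compounds named here, the only measured step, an 8.3-fold lower number from compound 1 to compound 2 (0.92 log units; beyond the scatter) for cyano in place of hydrogen, involves a different change, so no measurement shows the direction of this swap. In this assay the estimated step, a 1.8-fold higher number from compound 2 to compound 3 (0.24 log units; within the scatter), is expected to stay within the scatter. The estimate for compound 3 is 7 nM with 2 nM to 30 nM as its expected range.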

Compound 3, concentration for 50% growth inhibition: 17 nM
Compound 3: the middle estimate sits 2.4-fold (0.39 log units) below what was measured; low and high end bracket the measured number.
By their numbers in this assay, from the lowest: compound 2; then compounds 3 and 1 (each within the scatter of the next).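

For the compounds shown here, this is the first measurement at the aromatic carbon ortho to a cyano group: in this assay, 1H-indazol-3-yl in place of 1H-indol-3-yl gives a 4.3-fold higher number from compound 2 to compound 3 (0.63 log units; beyond the scatter). The two groups have the same count of heavy atoms, so exchanging one carbon for one nitrogen is enough to shift the number beyond the scatter here. Nothing measured here accounts for this shift.

Still open, from the compounds shown here alone, is how a different group at this position, such as a phenyl ring or a simple amine, would compare. Going by these compounds, it is also open whether 1H-indazol-3-yl would give a similar step on the core of compound 1, which has hydrogen in place of the cyano group.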